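The source may hold more compounds than are shown below. What is called first, only, known or untested is meant among the compounds shown, and "the series" means these compounds.

Measured so far:
compound 1, `CCC(CC)Nc1nc(C)nc2c(-c3c(C)cc(N(C)C)nc3C)c(C)nn12`, 25.6 nM;
compound 2, `CCCCN(C)c1nc(C)nc2c(-c3ccc(OC)nc3C)c(C)nn12`, 8.1 nM;
compound 3, `CCC(CC)Nc1nc(C)nc2c(-c3cnc(OC)cc3C)c(C)nn12`, 3 nM.

All three were run in an assay on cell membranes for displacement of a labelled ligand from corticotropin-releasing factor receptor 1 (Rattus norvegicus); on this read-out lower numbers stand for stronger inhibition and higher numbers for weaker inhibition. Compound 2 stands second highest of the three numbers: compound 3 gives a lower number, compound 1 a higher one, and both gaps lie beyond the usual scatter of repeated measurements.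

Compound 4, `CCCC(C)Nc1nc(C)nc2c(-c3ccc(OC)nc3C)c(C)nn12`, has not been measured. Compared with compound 2 it differs in one place: (1-methylbutyl)amino in place of butyl(methyl)amino on an aromatic carbon. The two compounds contain the same atoms, joined differently.

Among the measured compounds shown here, no pair of measured compounds differs by exactly this change, so no measured step can be leaned on. Two measured compounds carry a related branched amino group rather than the butyl(methyl)amino group: compound 1 gave 25.6 nM, and compound 3 gave 3 nM, and these two numbers bracket the value of compound 2. The expected step is therefore small, most likely within the scatter, with a slight lean toward a lower number, expected as a 1.5-fold lower number from compound 2 to compound 4 (0.17 log units; within the scatter). For compound 4 the estimate in this assay is 5.5 nM, with a range from 1.8 nM to 17 nM.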

Compound 4, half-maximal inhibitory concentration: 3.5 nM
Compound 4: middle estimate off by 1.6-fold (0.20 log units), on the high side; low and high end bracket the measured number.
By their numbers in this assay, from the lowest: compounds 3 and 4 (each within the scatter of the next); then compound 2; then compound 1.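

Among the compounds shown here, a single swap on the aromatic carbon, (1-methylbutyl)amino in place of butyl(methyl)amino, gives in this assay a 2.3-fold lower number from compound 2 to compound 4 (0.36 log units; beyond the scatter) and is the first direct reading of this position. The step is modest but real, so rearranging the same atoms within this group is enough to shift the number, even with the rest of the molecule unchanged. The entering group carries a hydrogen-bond donor where the leaving group has none, but nothing measured here connects that difference, or any other, to the shift.

From the compounds shown here alone, it remains open whether the same swap would give a similar step with a different aromatic ring on the shared core. Also open, going by these compounds, is how a longer chain such as (1-methylhexyl)amino, or a cyclic amine such as morpholine, would fare at this position.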